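The compounds below may be only part of what the source reports. "The series", "measured", "known", "first", "only" and "open" are said of these compounds alone.

Compound 1 `Nc1scc(CN2CCN(c3ccc([N+](=O)[O-])cc3)CC2)c1C(=O)c1ccc(Cl)cc1` was tested in an assay on CHO cells for displacement of a labelled ligand from adenosine receptor A1 (Homo sapiens), read by scintillation counting, with a stated time of 120 min, tested at 10 uM (a higher number here means more inhibition at the concentration tested (going by the name of the read-out), a lower number less inhibition), and compound 1 gives 1% there. Within the data shown here, compound 2 `Nc1scc(CN2CCN(c3cccc(C(F)(F)F)c3)CC2)c1C(=O)c1ccc(Cl)cc1` gives 0% in the same assay, so compound 1 stands at the upper of the two numbers measured so far, although the step of a number 1 percentage points lower from compound 1 to compound 2 (within the scatter) lies within the scatter and the two compounds cannot be told apart on these data. Compound 3 `Nc1scc(CN2CCN(c3c(F)cccc3F)CC2)c1C(=O)c1ccc(Cl)cc1` differs from compound 1 in one place: 2,6-difluorophenyl in place of 4-nitrophenyl on an amine nitrogen in a ring. Among the measured compounds shown here, the only measured step that bears on this change is a number 1 percentage points lower from compound 1 to compound 2 (within the scatter), which exchanged the aryl group on the same ring nitrogen and produced no movement beyond the scatter. Compound 3 is therefore expected to show no step beyond the scatter either, no change at the digits printed from compound 1 to compound 3 (within the scatter). On that basis compound 3 is estimated at 1%, with a range from -8% to 10%.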

Compound 3, a percentage reported as inhibition, at one concentration (the size of the read-out at that concentration, not a potency): 1%
Beside the measured number, compound 3's estimate shows no gap at the digits printed; the range from low to high includes it.
By their numbers in this assay, from the lowest: compounds 2, 1 and 3 (each within the scatter of the next).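

In this assay, a third aryl group on the ring nitrogen again leaves the number within the scatter: no change at the digits printed from compound 1 to compound 3 (within the scatter), and a number 1 percentage points higher from compound 2 to compound 3 (within the scatter). The exchange of 4-nitrophenyl, with its 2 hydrogen-bond acceptors, for 2,6-difluorophenyl, with 0, thus comes with no step beyond the scatter, and none of the three aryl groups can be told apart at this position. Nothing available accounts for these numbers or says why the aryl exchanges leave them within the scatter.

On these data alone, all three compounds keep the rest of the shared core, so it remains open whether an aryl group bearing a carboxylic acid or an amine, or a plain alkyl chain on that ring nitrogen, would give a number beyond the scatter. Also open, as far as these compounds go, is whether a methoxy group in place of the chlorine would do so.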